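The compounds below may be only part of what the source reports. "The series", "measured", "known", "first", "only" and "open" are said of these compounds alone.

Measured so far:
compound 1 `CCOC(=O)C1=C(C)NC(SC)=NC1c1cccc([N+](=O)[O-])c1`, 23 nM
compound 2 `COC(=O)C1=C(C)N=C(SC)NC1c1cccc([N+](=O)[O-])c1`, 120 nM
compound 3 `CSC1=NC(c2cccc([N+](=O)[O-])c2)C(C(=O)OC(C)C)=C(C)N1`, 12 nM

All three share one core, an ester group and a nitrophenyl ring, and differ in what hangs on the ester oxygen. In an assay on Myocardium (Cavia porcellus) for binding affinity to Voltage-dependent L-type calcium channel subunit alpha-1C (Homo sapiens) (a lower number here means tighter binding, a higher number weaker binding), compound 1 gives 23 nM, the second highest of the three numbers. Compound 3 sits closest to it: the step of a 1.9-fold lower number from compound 1 to compound 3 (0.28 log units; within the scatter) stays within the scatter of repeated measurements. Compound 2 is the furthest away, its number being higher than that of compound 1 and beyond the scatter.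

Compound 4 `CCC(C)OC(=O)C1=C(C)NC(SC)=NC1c1cccc([N+](=O)[O-])c1` has not yet been measured. It differs from compound 1 in one place: ethyl in place of hydrogen on a saturated chain carbon bound to an oxygen next to a carbonyl group and a saturated chain carbon. Read one bond further out, the ethyl ester of compound 1 becomes a sec-butyl ester.

For the measured compounds named here, the one measured step that bears on this is the step from compound 1 to compound 3, where a methyl was put at the same carbon, and that step was small and within the scatter. Adding ethyl at that carbon is a longer extension of the same kind, so in this assay the step of a 1.5-fold lower number from compound 1 to compound 4 (0.19 log units; within the scatter) is expected to be small as well, with the number for compound 4 tending, if anything, a little lower than that of compound 1. Compound 4 is estimated at 15 nM, with a likely range from 5 nM to 45 nM.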

Compound 4, dissociation constant: 2.6 nM
Estimate against measurement, compound 4: 5.8-fold (0.76 log units) above; the whole stated range lies above it.
By their numbers in this assay, from the lowest: compound 4; then compounds 3 and 1 (each within the scatter of the next); then compound 2.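

The earlier compounds shown here suggested that this carbon, bound to the ester oxygen, tolerates change without much effect on the number in this assay, yet ethyl in place of hydrogen there gives an 8.8-fold lower number from compound 1 to compound 4 (0.95 log units; beyond the scatter) and so moves the value well beyond the scatter. The extra methyl on a saturated chain carbon, two bonds along the chain from the oxygen next to the carbonyl group, separates the two branched esters and gives a 4.6-fold lower number from compound 3 to compound 4 (0.66 log units; beyond the scatter) as a one-place change, which shows that the outer part of the sec-butyl group matters here and that the size of the effect does not grow evenly with each added carbon. The measurements shown give no reason for a change of this size.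

Going by these compounds, whether a longer chain such as hexyl, or a ring such as cyclohexyl, on this carbon would lower the number further or reverse the trend remains open. Also open, on these data alone, is how an amine or a carboxylic acid at the end of the sec-butyl chain would affect binding.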